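The compounds below may be only part of what the source reports. "The series", "measured", "known", "first", "only" and "open" are said of these compounds alone.

Working notes on the shared core, compounds 1 to 4.

Compound 1 `COCOCc1ccc(-c2cnc(C(=O)CCCCCCc3ccccc3)o2)nc1` gives 10.1 nM in an assay for inhibition of Fatty-acid amide hydrolase 1 (Rattus norvegicus), using a Dixon plot; on this read-out higher numbers stand for weaker inhibition and lower numbers for stronger inhibition. Compound 2 `C[S+]([O-])/C=C/c1ccc(-c2cnc(C(=O)CCCCCCc3ccccc3)o2)nc1` gives 3 nM in this assay. Within that pair the change is a 3.4-fold lower number from compound 1 to compound 2 (0.53 log units; beyond the scatter). Compound 3 `O=CCCCCc1cnc(C(=O)CCCCCCc2ccccc2)o1` gives 14.6 nM in this assay, which is the highest of the three numbers recorded; compound 3 and compound 1 lie within the scatter of each other, so no order between them is claimed, while compound 2 stands beyond the scatter from compound 3.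

Compound 4 `O=C(CCCCCCc1ccccc1)c1ncc(CCCCCCl)o1` is not yet measured. It differs from compound 3 by chloromethyl in place of formyl on a saturated chain carbon, four bonds along the chain from an aromatic carbon. Going by the values given here, no measured step bears directly on this change: the only measured step, that from compound 1 to compound 2, concerns a group on an aromatic carbon, not the end of the saturated chain, and the three measured compounds all lie within a narrow band in this assay. Among the compounds with values here, with no step of this kind on record, a step no larger than the scatter, in either direction, is expected for the change a 1.2-fold higher number from compound 3 to compound 4 (0.09 log units; within the scatter). Compound 4 is therefore estimated at 18 nM in this assay, with a range from 6 nM to 55 nM.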

Compound 4, inhibition constant: 5.2 nM
For compound 4 the middle estimate is 3.5-fold (0.54 log units) above the measured one; the measured number lies below the stated range.
By their numbers in this assay, from the lowest: compounds 2, 4, 1 and 3 (each within the scatter of the next, the first and the last beyond it).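

In this assay, going by these compounds alone, the end of the saturated chain proves to be a place where a change registers: chloromethyl in place of formyl, four bonds along the chain from an aromatic carbon, gives a 2.8-fold lower number from compound 3 to compound 4 (0.45 log units; beyond the scatter) and is the first step on record at this place, the earlier step being on an aromatic carbon. The two groups match in their count of heavy atoms and differ in that formyl brings a double bond and a hydrogen-bond acceptor while chloromethyl brings chlorine and neither of those, yet a single pair cannot show which of these differences goes with the step. Nothing on record accounts for the step.

On these data alone, it stays open whether the step follows from the arrival of chlorine or from the departure of formyl, a question that a plain methyl, a hydroxymethyl, a bromomethyl or a carboxylic acid at the same place would help to settle. Also open, as far as these compounds go, is how the step depends on chain length, since a shorter or a longer chain ending in the same chlorine-bearing carbon would test whether this place is specific.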